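A few compounds are considered here, and "the series" means these few. Any claim that something is new, unique, unknown or untested is made for them only; others in the source may bear on it.

Measured so far in a functional assay for antagonist activity at P2Y purinoceptor 1 (Homo sapiens); a lower number here means a stronger inhibitor, a higher number a weaker inhibitor:
compound 1 `CNc1ncnc2c1ncn2[C@H]1C[C@H](OP(=O)(O)O)[C@]2(COP(=O)(O)O)C[C@H]12`: 157 nM
compound 2 `CNc1nc(C)nc2c1ncn2[C@H]1C[C@H](OP(=O)(O)O)[C@]2(COP(=O)(O)O)C[C@H]12`: 49 nM

Compound 2 holds the lowest number of the two; its nearest neighbour is compound 1, set apart by a 3.2-fold lower number from compound 1 to compound 2 (0.51 log units; beyond the scatter). The next compound, compound 3 `CCCCCCc1nc(NC)c2ncn([C@H]3C[C@H](OP(=O)(O)O)[C@]4(COP(=O)(O)O)C[C@H]34)c2n1`, carries the change (pentyl in place of hydrogen on a saturated chain carbon bound to an aromatic carbon), which, cut one bond further out, reads as methyl to hexyl on the same aromatic carbon where the step from compound 1 to compound 2 was made. That one step is the only measured one that bears on the new change, and it concerned the first carbon only; nothing measured tells how a longer chain at this place behaves. A step for compound 3 is therefore expected to be small and with no assured direction, with a moderate loss taken as the more likely case. The expected step is a 3.1-fold higher number from compound 2 to compound 3 (0.49 log units; beyond the scatter). Compound 3 is estimated at 150 nM, within 40 nM to 600 nM in this assay.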

Compound 3, half-maximal inhibitory concentration: 452 nM
Compound 3: the middle estimate sits 3.0-fold (0.48 log units) below what was measured, and the stated range covers the measured number.
By their numbers in this assay, from the lowest: compound 2; then compound 1; then compound 3.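

In this assay, lengthening the group on this aromatic carbon from methyl to hexyl does not carry the earlier gain forward: pentyl in place of hydrogen on the saturated chain carbon gives a 9.2-fold higher number from compound 2 to compound 3 (0.96 log units; beyond the scatter) and more than cancels what the first carbon gained. Measured against hydrogen at the same place, hexyl gives a 2.9-fold higher number from compound 1 to compound 3 (0.46 log units; beyond the scatter) and so leaves the compound weaker than the one with no substituent there. This place therefore does not answer in one direction to added carbon, since methyl lowers the number relative to hydrogen while hexyl raises it.

Open, from the compounds shown here alone, is where between methyl and hexyl the number turns, and whether ethyl, propyl, a branched chain such as isopropyl, or an amine on this aromatic carbon would match or improve on compound 2. No supporting data at hand account for the reversal.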